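The compounds below may be only part of what the source reports. "The series", "measured", "known", "first", "only" and "open" are said of these compounds alone.

Working notes on the series. Compound 1 `CC1CC/C(=N\Nc2ccccc2)c2ncc(C(N)=O)c(=O)n21`, compound 2 `CC1CCn2c(ncc(C(=O)O)c2=O)/C1=N/Nc1ccccc1` and compound 3 `CC1CC/C(=N\Nc2ccccc2F)c2ncc(C(=O)O)c(=O)n21` share one core and have all been run in a functional assay on the whole organism for inhibition, with Rattus norvegicus as the target; a higher number here means that more compound is needed for the effect, a lower number that less compound is needed. In this assay compound 1 gives only a limit, > 1000 umol/kg. Compound 2 likewise gives only a limit in this assay, > 320 umol/kg. Compound 3 also stands at a limit in this assay, > 1000 umol/kg, and this is the position from which the next step is taken. Two of the three values sit at one limit (the limit of > 1000 umol/kg in this assay, at which 2 of the 3 values shown sit) and one at another (the limit of > 320 umol/kg in this assay, at which 1 of the 3 values shown sits). Among the compounds with values here, no step between measured compounds is on record, so the three values show only that no compound reached a dose for half inhibition within the tested range. Compound 4 `Cc1cccc(N/N=C2\CCC(C)n3c2ncc(C(=O)O)c3=O)c1` is the next compound, not yet measured in this assay. Its change from compound 3 is 3-methylphenyl in place of 2-fluorophenyl on an amine nitrogen. With every measured value a limit, no direction can be read from the series. The step of a number no higher from compound 3 to compound 4 (the limit leaves the size open) is expected to stay within the scatter. Compound 4 is expected to give 1000 umol/kg in this assay, between 300 umol/kg and 3000 umol/kg, most probably reported again as a limit.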

Compound 4, dose for 50% inhibition: 72.5 umol/kg
For compound 4 the middle estimate is 14-fold (1.14 log units) above the measured one, outside the stated range (below it).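

In this assay the series now holds its first readable step: with 3-methylphenyl in place of 2-fluorophenyl on an amine nitrogen, the change is an at least 13-fold lower number from compound 3 to compound 4 (1.13 log units; beyond the scatter) and the rest of the structure stays the same. The read-out therefore responds to the aryl group at this place, and compound 4 is the first compound shown with a dose for half inhibition that is a number and not a limit. Nothing measured here accounts for the size of the step.

Compound 2, with unsubstituted phenyl at this place, gives only a limit, > 320 umol/kg, and so offers no reference point. On these data alone, whether the methyl group or the loss of the fluorine carries the step stays open, as does how a methoxy group, a chlorine atom or a longer alkyl chain on that ring would read.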